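Trimming the Sulfonamide Chain from Butyl to Methyl

The compounds below may be only part of what the source reports. "The series", "measured", "known", "first", "only" and "open" are said of these compounds alone.

Measured so far:
compound 1 `CC[C@@H]1C(=O)N(C)c2cnc(Nc3ccc(S(=O)(=O)NC4CCCC4)cc3)nc2N1C1CCCC1` gives 1710 nM in a functional assay on NCI-H1975 cells (Homo sapiens) for antiproliferative activity, read by CCK-8 assay, with a stated time of 72 h; on this read-out higher numbers stand for weaker inhibition of growth and lower numbers for stronger inhibition of growth;
compound 2 `CCCCNS(=O)(=O)c1ccc(Nc2ncc3c(n2)N(c2ccn(C)n2)C(CC)C(=O)N3C)cc1` gives 4120 nM in the same test.

Going by the values given here, of the two compounds measured, compound 2 shows the higher number, and the only neighbour it can be compared with is compound 1, whose number is lower by a margin that goes beyond the usual scatter of the test. The two compounds differ in several places at once, so no single change can be tied to that gap.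

Compound 3 `CCC1C(=O)N(C)c2cnc(Nc3ccc(S(=O)(=O)NC)cc3)nc2N1c1ccn(C)n1` has not yet been measured. It differs from compound 2 in one place: hydrogen in place of propyl on a saturated chain carbon bound to a sulfonamide nitrogen. No step between measured compounds isolates this kind of change, so the expectation rests on the two numbers shown and on the fact that the remaining parts of compound 2 are kept. The step is expected to be small, in the direction of a somewhat weaker inhibition of growth, or none beyond the scatter, read as a 1.3-fold higher number from compound 2 to compound 3 (0.10 log units; within the scatter). Compound 3 is therefore estimated to give 5200 nM, with a range from 1500 nM to 18000 nM.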

Compound 3, concentration for 50% growth inhibition: 18800 nM
Compound 3: middle estimate off by 3.6-fold (0.56 log units), on the low side, and the stated range ends below it.
By their numbers in this assay, from the lowest: compound 1; then compound 2; then compound 3.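

In this assay the change from butyl to methyl gives a 4.6-fold higher number from compound 2 to compound 3 (0.66 log units; beyond the scatter) and this step lies beyond the scatter of the test. Going by these compounds alone, it is the first step here that isolates a single change, since compound 1 and compound 2 differ in several places at once. With the rest of compound 2 kept, it shows that this place is not indifferent to what it carries: hydrogen in place of propyl on a saturated chain carbon bound to a sulfonamide nitrogen goes with weaker inhibition of growth, and nothing at hand accounts for that shift.

The compounds shown leave open how the number follows chain length, as a single step cannot tell whether an ethyl chain would stand close to butyl or close to methyl, or whether a hexyl chain would lower the number further. They also leave open whether a chain ending in an amine or a carboxylic acid would be accepted here, and whether the same step would appear on the other parts of compound 1.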